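Working notes on the series: compound 1 to compound 3

A few compounds are considered here, and "the series" means these few. Any claim that something is new, unique, unknown or untested is made for them only; others in the source may bear on it.

Going by the values given here, compound 1 `COOC1(OOC)CCCCCCCCCCC1` stands at the lowest of the two numbers so far obtained in a functional assay on FM3A cells (Mus musculus) for cytotoxicity; on this read-out higher numbers stand for an effect only at larger amounts of compound and lower numbers for an effect already at smaller amounts; in this assay compound 1 gives 1500 nM. Among the compounds with values here, its only measured neighbour, compound 2 `C=C(C)COOC1(OOC)CCCCCCCCCCC1`, gives 17000 nM in this assay, the step between them being an 11-fold higher number from compound 1 to compound 2 (1.05 log units; beyond the scatter). Compound 3 `COOC1(OOCCC(=O)OC)CCCCCCCCCCC1` is not yet measured; it differs from compound 1 by (methoxycarbonyl)methyl in place of hydrogen on a saturated chain carbon bound to an oxygen. Within the data shown here, the single step that bears on this change, an 11-fold higher number from compound 1 to compound 2 (1.05 log units; beyond the scatter), brings in a different group, yet at the same kind of place and likewise lengthening the methoxy of compound 1, and it moved the number up by a large amount. Extension at this point is therefore expected to raise the number in this assay, though with an untested entering group the step is expected at a 4.0-fold higher number from compound 1 to compound 3 (0.60 log units; beyond the scatter). For compound 3 the estimated value is 6000 nM, with a range from 1500 nM to 25000 nM.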

Compound 3, half-maximal effective concentration: 1400 nM
Compound 3: the middle estimate sits 4.3-fold (0.63 log units) above what was measured, outside the stated range (below it).
By their numbers in this assay, from the lowest: compounds 3 and 1 (each within the scatter of the next); then compound 2.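

In this assay the extension at this position does not by itself move the number: the step reads a 1.1-fold lower number from compound 1 to compound 3 (0.03 log units; within the scatter) and lengthens methoxy to 2-(methoxycarbonyl)ethoxy. The large rise seen with 1-methylethenyl is therefore not shared by every group entering on this saturated chain carbon bound to an oxygen, and exchanging that group for (methoxycarbonyl)methyl gives a 12-fold lower number from compound 2 to compound 3 (1.08 log units; beyond the scatter) in the same assay. Nothing at hand accounts for the different outcomes of these two entering groups.

As far as these compounds go, it remains open whether the outcome for compound 3 depends on the methyl ester or on the chain that carries it. A carboxylic acid, an amine or a plain longer alkyl chain at this place would help to separate these readings.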